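Moving the chlorine on the aryl group of compound 1

The compounds below may be only part of what the source reports. "The series", "measured", "known", "first", "only" and "open" are said of these compounds alone.

Within the data shown here, compound 1 `Cn1c(-c2cccc(Cl)c2)nc2c(NC3CCCC3)ncnc21` gives 2530 nM in a functional assay on CHO cells for antagonist activity at adenosine receptor A2b (Homo sapiens), read by 33P incorporation, with a stated time of 20 min (a higher number here means a weaker inhibitor, a lower number a stronger inhibitor), the lowest of the two numbers so far; compound 2 `CCCn1c(-c2ccccc2)nc2c(NC3CCCCC3)ncnc21` gives 5310 nM in this assay, a difference beyond the usual scatter. Compound 3 `Cn1c(-c2ccccc2Cl)nc2c(NC3CCCC3)ncnc21` is not yet measured. It differs from compound 1 by 2-chlorophenyl in place of 3-chlorophenyl on an aromatic carbon. Among the measured compounds shown here, no measured pair shows this kind of change, so its effect is unknown. A modest step is expected, a 1.4-fold higher number from compound 1 to compound 3 (0.14 log units; within the scatter), most likely toward a weaker inhibitor. Compound 3 is therefore estimated at 3500 nM in this assay, with a range from 1000 nM to 12000 nM.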

Compound 3, inhibition constant: > 30000 nM
Compound 3 was reported as a limit (the forecaster's own chance of this, stated with the estimate: 5%); middle value at least 8.5-fold (0.93 log units) away from the limit.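

In this assay, moving only the chlorine, with the atoms of the group unchanged, makes a large difference at this carbon between two ring nitrogen atoms: the change gives an at least 11-fold higher number from compound 1 to compound 3 (1.07 log units; beyond the scatter). The chlorine's place on the aryl group therefore matters here, not just its presence. For compound 3 the result is a limit of the assay, not a number: the limit of > 30000 nM in this assay, at which 1 of the 3 values shown sits.

As far as these compounds go, the true size of the step stays unknown. Also open, from the compounds shown here alone, is whether a fluorine or a methoxy group in place of the chlorine of the 2-chlorophenyl group would give a similar result.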